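Furan to thiophene swap on the saturated ring carbon

This account rests on a few compounds, and the source may have more. Where it says the series, first, only, none or still open, it means among the compounds named here.

The three measured compounds share one core and differ only in the aryl group on the carbonyl carbon. Compound 1 `COc1cc(-c2nnc3n2NC(c2ccco2)C(C(=O)c2ccccc2C)S3)cc(OC)c1OC` carries a 2-methylphenyl there, compound 2 `COc1cc(C(=O)C2Sc3nnc(-c4cc(OC)c(OC)c(OC)c4)n3NC2c2ccco2)cc(OC)c1OC` a 3,4,5-trimethoxyphenyl, and compound 3 `COc1cc(-c2nnc3n2NC(c2ccco2)C(C(=O)c2ccc(Br)cc2)S3)cc(OC)c1OC` a 4-bromophenyl. In a functional assay on PC-3 cells (Homo sapiens) for cytotoxicity, read by MTT assay, with a stated time of 48 h (a higher number here means a weaker inhibitor, a lower number a stronger inhibitor), compound 1 gives 88400 nM. In this assay compound 2 gives 52200 nM, the second highest of the three numbers. In this assay compound 3 gives 36400 nM. The steps of a 1.7-fold lower number from compound 1 to compound 2 (0.23 log units; within the scatter) and a 1.4-fold lower number from compound 2 to compound 3 (0.16 log units; within the scatter) both stay within the scatter, while the step of a 2.4-fold lower number from compound 1 to compound 3 (0.39 log units; beyond the scatter) is modest.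

Compound 4 `COc1cc(C(=O)C2Sc3nnc(-c4cc(OC)c(OC)c(OC)c4)n3NC2c2cccs2)cc(OC)c1OC` differs from compound 2 in one place: thiophen-2-yl in place of furan-2-yl on a saturated ring carbon. For the measured compounds named here, no measured step touches this position; all three measured steps concern the group on the carbonyl carbon, and even there the largest of them, a 2.4-fold lower number from compound 1 to compound 3 (0.39 log units; beyond the scatter), is modest. Nothing in the measured set points to a change beyond the scatter for a swap of furan-2-yl for thiophen-2-yl, so compound 4 is expected to sit close to compound 2, with an expected step of a 1.0-fold lower number from compound 2 to compound 4 (0.02 log units; within the scatter). Compound 4 is therefore estimated at 50000 nM in this assay, with a range from 22000 nM to 110000 nM.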

Compound 4, half-maximal inhibitory concentration: > 100000 nM
Compound 4: no number, only a limit; the forecaster's own chance of this, stated with the estimate: 5%; middle value at least 2.0-fold (0.30 log units) away from the limit.
By their numbers in this assay, from the lowest: compounds 3, 2 and 1 (each within the scatter of the next, the first and the last beyond it). At a limit, above all of these: compound 4.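

Compound 4 reads in this assay as a limit of the assay and not as a number: the limit of > 100000 nM in this assay, at which 1 of the 4 values shown sits.

For the compounds shown here, this is the first reading at the saturated ring carbon, since all earlier steps concerned the aryl group on the carbonyl carbon. With thiophen-2-yl in place of furan-2-yl there, the step is an at least 1.9-fold higher number from compound 2 to compound 4 (0.28 log units; that floor lies within the scatter), which gives only a floor, and that floor does not separate the two compounds beyond the scatter. The swap therefore gives no lower number, while the true size of the step stays unbounded on the upper side and may exceed a 2.4-fold lower number from compound 1 to compound 3 (0.39 log units; beyond the scatter), the largest step seen on the carbonyl carbon.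

Still open is how a phenyl, a pyridin-2-yl or a chain ending in an amine would read on the saturated ring carbon, as only the two five-membered aromatic rings are shown at this position. Also open, as far as these compounds go, is whether thiophen-2-yl gives a similar reading when paired with the 4-bromophenyl of compound 3 or the 2-methylphenyl of compound 1, rather than with the 3,4,5-trimethoxyphenyl of compound 2.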